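Aryl exchange on the shared core: working notes

The source may hold more compounds than are shown below. What is called first, only, known or untested is meant among the compounds shown, and "the series" means these compounds.

compound 1 `COC(=O)/C(=C/c1ccccc1)CN1C(=O)[C@@H](OC)[C@H]1c1ccc(Cl)cc1` gives 37900 nM
compound 2 `COC(=O)/C(=C/c1ccccc1)CN1C(=O)[C@@H](OC)[C@H]1c1ccccc1C(F)(F)F` gives "not toxic" (no number reported)

In an ADME assay on cells (Epithelial cell, Homo sapiens) for antiproliferative activity, read by MTT assay, with a stated time of 48 h (a higher number here means a weaker inhibitor, a lower number a stronger inhibitor), compound 2 has no single number (reported as "not toxic" (no number reported)), whereas compound 1 has one (37900 nM). Compound 3 (`COC(=O)/C(=C/c1ccccc1)CN1C(=O)[C@@H](OC)[C@H]1c1ccc(F)cc1`) carries 4-fluorophenyl in place of 2-(trifluoromethyl)phenyl on a saturated ring carbon. For the measured compounds named here, no measured step between compounds differing in one place exists, so the size of this step cannot be read from the data. The expected direction runs from the unquantified result of compound 2 towards a reportable number in this assay, close to compound 1 (37900 nM). The estimated value for compound 3 is 40000 nM (expected range 12000 nM to 100000 nM).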

Compound 3, half-maximal inhibitory concentration: 27900 nM
Beside the measured number, compound 3's estimate is 1.4-fold (0.16 log units) above it, within the range that was stated.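

Fluoro in place of chloro on an aromatic carbon gives a 1.4-fold lower number from compound 1 to compound 3 (0.13 log units; within the scatter) in this assay, so this exchange does not separate the two halogens in this assay. With 4-fluorophenyl on the saturated ring carbon, compound 3 has a reportable number, whereas compound 2, with 2-(trifluoromethyl)phenyl there, has none, so the size of that step cannot be read. No supporting data bear on these results. As far as these compounds go, whether an amine or a carboxylic acid on the aryl group would move the number in this assay stays open, as does the result of a longer chain in place of the methoxy group.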